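Urea substituent swap on the shared core

The source may report more compounds than this note shows. Statements on the series, on what has been measured and on what is new or still open speak of the compounds shown alone.

Compound 2 `O=C(Nc1cccc(CNc2nccnc2Cl)c1)NC1CCCCC1` has been tested in a functional assay on T-24 cells (Homo sapiens) for antiproliferative activity, read by MTT assay, with a stated time of 48 h; on this read-out higher numbers stand for weaker inhibition and lower numbers for stronger inhibition. In this assay compound 2 gives > 40000 nM, which is a limit of the assay and not a number. Compound 3 `O=C(Nc1ccc(Cl)cc1)Nc1cccc(CNc2nccnc2Cl)c1` differs from it by 4-chlorophenyl in place of cyclohexyl on an amide-type nitrogen. Among the measured compounds shown here, one measured step bears on this change: compound 1 `Cc1ccc(NC(=O)Nc2cccc(CNc3nccnc3Cl)c2)cc1Cl`, which in this assay gives 7390 nM, moves by an at least 5.4-fold higher number from compound 1 to compound 2 (0.73 log units; beyond the scatter). That step is bounded by the limit of > 40000 nM in this assay, at which 1 of the 2 values shown sits. The change to compound 3 runs the opposite way, so a lower number is expected, by an at least 4.0-fold lower number from compound 2 to compound 3 (0.60 log units; beyond the scatter). Compound 3 is therefore estimated at 10000 nM, within 3500 nM to 30000 nM.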

Compound 3, half-maximal inhibitory concentration: 5470 nM
Estimate against measurement, compound 3: 1.8-fold (0.26 log units) above; the measured number falls inside the stated range.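

With 4-chlorophenyl on the amide-type nitrogen, a second aryl group also stands clear of cyclohexyl in this assay, with an at least 7.3-fold lower number from compound 2 to compound 3 (0.86 log units; beyond the scatter). Compound 2 sits at a limit of the assay, so this step gives only a minimum size: the limit of > 40000 nM in this assay, at which 1 of the 3 values shown sits. The two aryl groups are not separated in this assay, with a 1.4-fold lower number from compound 1 to compound 3 (0.13 log units; within the scatter).

Going by these compounds, whether an unsubstituted phenyl keeps this level remains open, so the part played by the chlorine is unresolved. Also open, on these data alone, is where a pyridine ring or an open-chain butyl group would fall.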